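The source may hold more compounds than are shown below. What is called first, only, known or untested is meant among the compounds shown, and "the series" means these compounds.

Measured so far, in a functional assay on HBL-100 cells (Homo sapiens) for inhibition, read by sulforhodamine B assay, with a stated time of 48 h; on this read-out lower numbers stand for stronger inhibition of growth and higher numbers for weaker inhibition of growth:
- compound 1, `CC(=O)OC/C(=C\c1ccc(Cl)cc1)C(=O)c1ccccc1`, gives 2300 nM
- compound 2, `CC(=O)OC/C(=C\c1ccccc1F)C(=O)c1ccccc1`, gives 17000 nM
- compound 3, `CC(=O)OC/C(=C\c1ccc(Cl)cc1Cl)C(=O)c1ccccc1`, gives 3100 nM

Of these three numbers, compound 1 has the lowest, though its gap to compound 3 lies within the scatter of this assay; only compound 2 is clearly set apart, with a 7.4-fold higher number from compound 1 to compound 2 (0.87 log units; beyond the scatter). The step of a 1.3-fold higher number from compound 1 to compound 3 (0.13 log units; within the scatter) shows that adding a second chloro to the ring of compound 1 leaves the number essentially where it was.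

Compound 4, `CC(=O)OC/C(=C\c1ccc([N+](=O)[O-])cc1)C(=O)c1ccccc1`, has not yet been measured. It differs from compound 1 in one place: nitro in place of chloro on an aromatic carbon. Among the measured compounds shown here, no measured step swaps one group for another at this same position, so the nearest guide is the step from compound 1 to compound 3, which touched the same ring and stayed within the scatter, while the larger change from compound 1 to compound 2 altered a different position of the ring and is a weaker guide here.

On that basis the change is expected to leave this assay about where compound 1 stands, with a step of a 1.3-fold higher number from compound 1 to compound 4 (0.12 log units; within the scatter), and compound 4 is estimated at 3000 nM, with a likely range from 1000 nM to 12000 nM.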

Compound 4, concentration for 50% growth inhibition: 10000 nM
Compound 4: the middle estimate sits 3.3-fold (0.52 log units) below what was measured; the range from low to high includes it.
By their numbers in this assay, from the lowest: compounds 1 and 3 (each within the scatter of the next); then compounds 4 and 2 (each within the scatter of the next).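

The group on this aromatic carbon, para to a large group, does matter in this assay: nitro in place of chloro gives a 4.3-fold higher number from compound 1 to compound 4 (0.64 log units; beyond the scatter), so growth inhibition is weaker with nitro. Among the compounds shown here, the earlier compounds did not show this, since the only ring change that kept the rest of compound 1 intact, the added chloro of compound 3, stayed within the scatter, and this is the first swap of one group for another at this place. The swap replaces a single chlorine atom with a group of three heavy atoms and two hydrogen-bond acceptors, but nothing shown links either difference to the weaker inhibition, and no supporting measurement is available to explain it.

Going by these compounds, with only chloro and nitro at this place, two groups cannot show a trend, and it remains open how an amine, a methoxy group or a plain hydrogen there would compare with compound 1. On these data alone, it also remains open whether nitro would give a similar step on another aromatic carbon of the ring, or in the presence of the second chloro of compound 3.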